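Swapping One Five-Membered Ring for Another: Cytotoxicity Outlook

This account rests on a few compounds, and the source may have more. Where it says the series, first, only, none or still open, it means among the compounds named here.

Compound 1 `CCCCNc1nc(N)nc2ccn(CC(=O)NC)c12` sits at a limit of the assay in an ADME assay on HEK293 cells (Homo sapiens) for cytotoxicity, read by ATP content, with a stated time of 6 h; on this read-out lower numbers stand for higher toxicity in this test and higher numbers for lower toxicity in this test: > 24000 nM.
Compound 2 `CCCCNc1nc(N)nc2ccn(Cc3cccc(C)n3)c12` also sits at a limit of the assay in this assay: > 24000 nM.
Compound 3 `Cc1nnc(CNc2nc(N)nc3ccn(Cc4ccccn4)c23)o1` likewise sits at a limit of the assay in this assay: > 24000 nM.

Compound 3 therefore stands exactly where every measured compound stands, namely at the limit of > 24000 nM in this assay, at which 3 of the 3 values shown sit. Among the compounds with values here, the only step between measured compounds that differ in one place is a step that the two limits leave unreadable from compound 1 to compound 2, and the two limits leave its size unreadable. Compound 4 `Cc1cc(CNc2nc(N)nc3ccn(Cc4ccccn4)c23)on1` differs from compound 3 in one place: 3-methyl-1,2-oxazol-5-yl in place of 5-methyl-1,3,4-oxadiazol-2-yl on a saturated chain carbon bound to a nitrogen on an aromatic ring. Within the data shown here, no measured step concerns this particular exchange, and the one step that exists cannot be read, so nothing in the numbers speaks for a move away from the shared limit. The step from compound 3 to compound 4 in this assay is thus expected to be a step that the limit leaves unreadable from compound 3 to compound 4, with the reading most probably ending again at a limit rather than a number. Compound 4 is estimated at 30000 nM in this assay, within a range of 12000 nM to 90000 nM.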

Compound 4, half-maximal cytotoxic concentration: > 24000 nM
Compound 4 was reported as a limit; the forecaster's own chance of this, stated with the estimate: 85%; the middle value is on the limit's open side.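

In this assay compound 4 gives > 24000 nM, which is a limit of the assay. Within the data shown here, compound 3 also stands at a limit, so no step between compound 3 and compound 4 can be read. The compounds shown leave open whether any of them would show cytotoxicity at a measurable concentration in this test.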